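The compounds below may be only part of what the source reports. "The series", "measured", "known", "first", "only" and "open" are said of these compounds alone.

Measured so far:
- compound 1 `Nc1nc(N/N=C/c2ccc(N3CCCC3)cc2)nc2c1ncn2[C@@H]1O[C@H](CO)[C@@H](O)[C@H]1O` — 5.1 nM
- compound 2 `Nc1nc(N/N=C/c2ccc3ncccc3c2)nc2c1ncn2[C@@H]1O[C@H](CO)[C@@H](O)[C@H]1O` — 9.8 nM
- compound 3 `Nc1nc(N/N=C/c2ccc[nH]2)nc2c1ncn2[C@@H]1O[C@H](CO)[C@@H](O)[C@H]1O` — 8 nM

In an assay on CHO-K1 cells for displacement of a labelled ligand from adenosine receptor A1 (Homo sapiens), read by scintillation counting, with a stated time of 60 min (a higher number here means a weaker inhibitor, a lower number a stronger inhibitor), compound 1 gives 5.1 nM, compound 2 gives 9.8 nM and compound 3 gives 8 nM. Compound 3 has the second highest of the three numbers; nearest is compound 2, with a 1.2-fold lower number from compound 2 to compound 3 (0.09 log units; within the scatter), and furthest is compound 1, with a 1.6-fold higher number from compound 1 to compound 3 (0.20 log units; within the scatter). All three values lie within the scatter of one another, so no order among them can be drawn.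

Compound 4 `Nc1nc(N/N=C/c2cncs2)nc2c1ncn2[C@@H]1O[C@H](CO)[C@@H](O)[C@H]1O` differs from compound 3 by 1,3-thiazol-5-yl in place of 1H-pyrrol-2-yl on a carbon with a double bond to nitrogen.

Every measured step in this series changes the group on the carbon with a double bond to nitrogen while the shared core stays fixed: a 1.9-fold higher number from compound 1 to compound 2 (0.28 log units; within the scatter), a 1.6-fold higher number from compound 1 to compound 3 (0.20 log units; within the scatter) and a 1.2-fold lower number from compound 2 to compound 3 (0.09 log units; within the scatter) are each within the scatter. Three exchanges of this group, differing widely in ring size and heteroatoms, have left this assay essentially unchanged. The exchange in compound 4 is of the same kind, so no step beyond the scatter is expected, a 1.1-fold higher number from compound 3 to compound 4 (0.05 log units; within the scatter). Compound 4 is estimated at 9 nM, within 4 nM to 20 nM.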

Compound 4, inhibition constant: 22 nM
Compound 4: the middle estimate sits 2.4-fold (0.39 log units) below what was measured; the whole stated range lies below it.
By their numbers in this assay, from the lowest: compounds 1, 3 and 2 (each within the scatter of the next); then compound 4.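

In this assay, within the data shown here, the group on the carbon with a double bond to nitrogen is no longer without effect: 1,3-thiazol-5-yl gives the first steps beyond the scatter (a 2.8-fold higher number from compound 3 to compound 4 (0.44 log units; beyond the scatter)) (a 2.2-fold higher number from compound 2 to compound 4 (0.35 log units; beyond the scatter)) (a 4.3-fold higher number from compound 1 to compound 4 (0.63 log units; beyond the scatter)), all modest, which leaves compound 4 the weakest of the four. The sharpest point is the exchange with 1H-pyrrol-2-yl: a five-membered aromatic ring replaced by another is enough to move the number, with 0 hydrogen-bond donors and 2 hydrogen-bond acceptors entering where 1 hydrogen-bond donor and 0 hydrogen-bond acceptors leave. No measurement at hand accounts for this step.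

Whether the lost hydrogen-bond donor or the entering sulfur matters remains unresolved, as both change in this one exchange. A thiophen-2-yl or furan-2-yl ring would bear on that, and a saturated amine or a carboxylic acid at this place remains an open case.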